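Bromo series: ethyl to isopropyl on the sulfonamide

A few compounds are considered here, and "the series" means these few. Any claim that something is new, unique, unknown or untested is made for them only; others in the source may bear on it.

Measured so far:
compound 1, `CC(C)NS(=O)(=O)Cc1noc2ccccc12`, 56 mg/kg
compound 2, `CCNS(=O)(=O)Cc1noc2ccc(Br)cc12`, 18 mg/kg

In a functional assay on the whole organism (strain STD-dd) with Mus musculus as the target, in the maximal electroshock model, with a stated time of 2 h (a higher number here means that more compound is needed for the effect, a lower number that less compound is needed), compound 2 gives the lowest of the two numbers in hand. Compound 1 gives a higher number in this assay, and that gap lies beyond the scatter. The two compounds differ in more than one place, so the gap cannot be assigned to either difference on its own.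

Compound 3, `CC(C)NS(=O)(=O)Cc1noc2ccc(Br)cc12`, has not been measured in this assay. It differs from compound 2 in one place: methyl in place of hydrogen on a saturated chain carbon bound to a saturated chain carbon and a sulfonamide nitrogen. For the measured compounds named here, no step between measured compounds isolates this change; compound 1 carries the isopropylamino group but lacks the bromine, so it offers no clean comparison.

With nothing to anchor the change, the expectation is a small step. The expected step is a 1.4-fold higher number from compound 2 to compound 3 (0.14 log units; within the scatter), toward a somewhat higher number, most likely within the scatter. Compound 3 is estimated at 25 mg/kg, with a range of 12 mg/kg to 50 mg/kg.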

Compound 3, dose for half-maximal effect: 22 mg/kg
Estimate against measurement, compound 3: 1.1-fold (0.06 log units) above, and the stated range covers the measured number.
By their numbers in this assay, from the lowest: compounds 2 and 3 (each within the scatter of the next); then compound 1.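

Replacing the ethylamino group with the isopropylamino group gives a 1.2-fold higher number from compound 2 to compound 3 (0.09 log units; within the scatter) in this assay and so does not separate the two compounds at this saturated chain carbon bound to a saturated chain carbon and a sulfonamide nitrogen. For the compounds shown here, with the isopropylamino group held constant, bromo in place of hydrogen on an aromatic carbon gives a 2.5-fold lower number from compound 1 to compound 3 (0.41 log units; beyond the scatter) and is the first change that can be read on its own. No measurement here gives a reason for either step.

Whether methyl in place of hydrogen stays without effect on larger groups is open, and a tert-butyl group, a cyclopropyl group or a longer chain on the sulfonamide nitrogen would bear on that. The reading for bromo also rests on a single pair carrying the isopropylamino group, which leaves open how chloro or methoxy on the same aromatic carbon would compare and whether bromo gives a similar step with other groups on the sulfonamide nitrogen.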